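From 4-methoxyphenyl to 2-chlorophenyl in compound 4

This account rests on a few compounds, and the source may have more. Where it says the series, first, only, none or still open, it means among the compounds named here.

compound 1 `CCN(CC)C(=S)SC(CC(=O)c1ccccc1)c1ccccc1Cl` gives 4500 nM
compound 2 `CCN(CC)C(=S)SC(CC(=O)c1ccc(Br)cc1)c1ccc(OC)cc1` gives 5000 nM
compound 3 `CCN(CC)C(=S)SC(CC(=O)c1ccc(OC)cc1)c1ccc(OC)cc1` gives 800 nM

In a functional assay on MCF7 cells (Homo sapiens) for cytotoxicity, read by MTT assay, with a stated time of 48 h (on this read-out lower numbers stand for stronger inhibition and higher numbers for weaker inhibition), compound 3 gives 800 nM as the lowest of the three numbers, and the other two lie beyond the scatter from it. Compound 4 `CCN(CC)C(=S)SC(CC(=O)c1ccc(OC)cc1)c1ccccc1Cl` has not been measured yet. It differs from compound 3 by 2-chlorophenyl in place of 4-methoxyphenyl on a saturated chain carbon bound to a saturated chain carbon and a sulfur. Within the data shown here, the one measured step (a 6.3-fold lower number from compound 2 to compound 3 (0.80 log units; beyond the scatter)) is methoxy in place of bromo, a different change at a different place, so it does not test this swap directly. It shows only how far a single change can move the number in this small set. Compound 1 carries the same 2-chlorophenyl and gives 4500 nM as its number, but it has no methoxy at all, so it is only a loose guide. Expected in this assay is a 2.3-fold higher number from compound 3 to compound 4 (0.35 log units; beyond the scatter) as an estimate of modest size toward weaker inhibition. For compound 4 the estimate is 1800 nM (expected range 600 nM to 5000 nM).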

Compound 4, half-maximal inhibitory concentration: 70 nM
For compound 4 the middle estimate is 26-fold (1.41 log units) above the measured one; the measured number lies below the stated range.
By their numbers in this assay, from the lowest: compound 4; then compound 3; then compounds 1 and 2 (each within the scatter of the next).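

In this assay, putting 2-chlorophenyl in place of 4-methoxyphenyl on the saturated chain carbon bound to a saturated chain carbon and a sulfur gives an 11-fold lower number from compound 3 to compound 4 (1.06 log units; beyond the scatter), so this position can move the number a long way, and toward stronger inhibition. The 2-chlorophenyl group does not achieve this alone, since adding a methoxy group to the other aromatic ring while keeping the 2-chlorophenyl gives a 64-fold lower number from compound 1 to compound 4 (1.81 log units; beyond the scatter), which shows that the low number of compound 4 needs both groups. No evidence at hand explains the size of either step.

Going by these compounds, whether a plain phenyl or a fluorophenyl at this place would keep the number low remains open. On these data alone, it is equally open whether an amine could stand in for the methoxy group.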